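A few compounds are considered here, and "the series" means these few. Any claim that something is new, unique, unknown or untested is made for them only; others in the source may bear on it.

Measured compounds so far:
- compound 1, `CN1CCC(CNS(=O)(=O)c2ccccc2Nc2cc(-c3ccc4ccn(C)c4c3)c3nccnc3c2)C1`: 4640 nM in an assay on lysate for inhibition of 6-phosphofructo-2-kinase/fructose-2,6-bisphosphatase 3 (Homo sapiens), with stated times of 0.5 min and 45 min; on this read-out lower numbers stand for stronger inhibition and higher numbers for weaker inhibition
- compound 2, `CC(=O)N1CCC(NC(=O)c2ccncc2Nc2cc(-c3ccc4ccn(C)c4c3)c3nccnc3c2)CC1`: 31300 nM in this assay

Of the two numbers in this assay, compound 2 gives the highest. Going by the values given here, its nearest neighbour is compound 1, whose value lies well below it, beyond the usual scatter; no single-point step between the two is defined, so the pair shows only that compound 1 sits at the stronger end and compound 2 at the weaker end of the series.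

Compound 3, `CN1CCC(N(C)C(=O)c2ccncc2Nc2cc(-c3ccc4ccn(C)c4c3)c3nccnc3c2)C1`, has not been measured. Relative to compound 2 it carries methyl(1-methylpyrrolidin-3-yl)amino in place of (1-acetylpiperidin-4-yl)amino on a carbonyl carbon. The change sits on a carbonyl carbon whose other neighbours are an aromatic carbon, leaving the rest of the shared core unchanged.

Among the compounds with values here, no measured step covers this exchange, so the direction can only be expected, not read from the data. In this assay the step is expected to be a 3.5-fold lower number from compound 2 to compound 3 (0.54 log units; beyond the scatter), a modest move toward a lower number. On that basis compound 3 is estimated at 9000 nM, with a range from 2500 nM to 32000 nM.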

Compound 3, half-maximal inhibitory concentration: 39700 nM
Beside the measured number, compound 3's estimate is 4.4-fold (0.64 log units) below it; the whole stated range lies below it.
By their numbers in this assay, from the lowest: compound 1; then compounds 2 and 3 (each within the scatter of the next).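

Going by these compounds alone, on the carbonyl carbon of the shared core, methyl(1-methylpyrrolidin-3-yl)amino in place of (1-acetylpiperidin-4-yl)amino gives a 1.3-fold higher number from compound 2 to compound 3 (0.10 log units; within the scatter) in this assay, so this pair offers the first direct reading at this position, and the two compounds cannot be told apart on this read-out. The exchange alters several features at once: a five-membered non-aromatic ring stands for a six-membered one, the hydrogen-bond donor count goes from 1 to 0, and the double bond outside aromatic rings is gone, yet the numbers stay within the scatter of each other, so this pair ties none of these features to a separate effect on the read-out. No independent measurement bears on why the two numbers lie so close.

On these data alone, the contribution of each feature remains open, as ring size, the amide hydrogen and the acetyl group vary together in this single pair. Also open, as far as these compounds go, is how a simple dimethylamino group or a piperidine carrying a carboxylic acid on the same carbonyl carbon would read in this assay, and whether any group there can give a number clearly apart from compound 2 and compound 3.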